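The source may hold more compounds than are shown below. What is called first, only, known or untested is meant among the compounds shown, and "the series" means these compounds.

Measured compounds:
compound 1 `Fc1ccc(Oc2cncc3sc(-c4nnn[nH]4)cc23)cc1`, 5.5 nM
compound 2 `Clc1ccc(Oc2cncc3sc(-c4nn[nH]n4)cc23)cc1`, 1.1 nM

In an assay for inhibition of CDK8/Cyclin C (Homo sapiens), read by fluorescence polarization (a lower number here means a stronger inhibitor, a higher number a weaker inhibitor), compound 1 gives 5.5 nM, the higher of the two numbers; compound 2 gives 1.1 nM, a gap that lies beyond the usual scatter. Compound 3 `CC(=O)Nc1ccc(Oc2cncc3sc(-c4nnn[nH]4)cc23)cc1` has not yet been measured. It differs from compound 1 by acetamido in place of fluoro on an aromatic carbon. Within the data shown here, no comparable step between measured compounds is known here, so the direction rests on little. A modest weakening beyond the scatter seems plausible, though it could well stay level. Compound 3 is expected to show 9 nM, within 2.5 nM to 35 nM, a step of a 1.6-fold higher number from compound 1 to compound 3 (0.21 log units; within the scatter).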

Compound 3, half-maximal inhibitory concentration: 2 nM
The estimate for compound 3 lay 4.5-fold (0.65 log units) above the measured number, and the stated range ends above it.
By their numbers in this assay, from the lowest: compounds 2 and 3 (each within the scatter of the next); then compound 1.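

In this assay, the aromatic carbon para to a large group accepts more than a single fluoro atom: acetamido in place of fluoro gives a 2.8-fold lower number from compound 1 to compound 3 (0.44 log units; beyond the scatter), a modest step toward the stronger end. A larger substituent carrying a hydrogen-bond donor and acceptor is therefore not penalised at this position on the core of compound 1. Nothing available accounts for the direction of this step.

Whether the amide itself matters stays open, since the compounds shown do not say what a plain amine or a methoxy group would give here. How a longer chain on the carbonyl would fare is also unknown.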